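The source may report more compounds than this note shows. Statements on the series, on what has been measured and on what is new or still open speak of the compounds shown alone.

Compound 1 `CC(C)=Cc1nc(Nc2ccccc2)c2cc([N+](=O)[O-])ccc2n1`: 50000 nM
Compound 2 `CC(C)=Cc1nc(Nc2cccc(C(F)(F)F)c2)c2cc([N+](=O)[O-])ccc2n1`: > 100000 nM, a limit
Compound 3 `CC(C)=Cc1nc(Nc2cccc(Br)c2)c2cc([N+](=O)[O-])ccc2n1`: > 15000 nM, a limit

All three were tested in an ADME assay on HepG2 cells (Homo sapiens) for cytotoxicity, read by MTT assay, with a stated time of 72 h; a lower number here means a stronger inhibitor, a higher number a weaker inhibitor. Compound 2 is known there only by its limit of > 100000 nM. For the measured compounds named here, the one readable step is an at least 2.0-fold higher number from compound 1 to compound 2 (0.30 log units; that floor lies within the scatter). The others, a step that the limit leaves unreadable from compound 1 to compound 3 and a step that the two limits leave unreadable from compound 2 to compound 3, cannot be sized, and all three change a different place from the one at issue here. Compound 4 `Cc1ccc(S(=O)(=O)Cc2nc(Nc3cccc(C(F)(F)F)c3)c3cc([N+](=O)[O-])ccc3n2)cc1` differs from compound 2 between two ring nitrogen atoms: ((4-methylphenyl)sulfonyl)methyl in place of 2-methylprop-1-en-1-yl on an aromatic carbon. Going by the values given here, no measured step bears directly on this change, so the expectation leans on compound 1, the only exact value at 50000 nM. A moderate move towards a lower number is expected: an at least 3.3-fold lower number from compound 2 to compound 4 (0.52 log units; beyond the scatter). For compound 4 the estimated value is 30000 nM, with an expected range of 10000 nM to 100000 nM.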

Compound 4, half-maximal inhibitory concentration: > 100000 nM
Compound 4: only a limit was reported; the forecaster's own chance of this, stated with the estimate: 55%; at least 3.3-fold (0.52 log units) between middle value and limit.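

In this assay, no step can be read from compound 2 to compound 4, because both are known only by the same limit: the limit of > 100000 nM in this assay, at which 2 of the 4 values shown sit.

The compounds shown leave open whether ((4-methylphenyl)sulfonyl)methyl in place of 2-methylprop-1-en-1-yl changes the number at all.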